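The source may report more compounds than this note shows. Statements on the series, on what has been measured and on what is new or still open speak of the compounds shown alone.

Measured so far in an ADME assay on BHK-21 cells (Mesocricetus auratus) for cytotoxicity, read by MTT assay, with a stated time of 72 h; on this read-out higher numbers stand for lower toxicity in this test and lower numbers for higher toxicity in this test:
- compound 1 `Cc1ccc(C2CC(c3ccccc3)=NN2c2ccc(S(N)(=O)=O)cc2)cc1` gives 7000 nM
- compound 2 `NS(=O)(=O)c1ccc(N2N=C(c3ccc(OCc4ccccc4)cc3)CC2c2ccc(Cl)cc2)cc1` gives 15000 nM

Compound 2 holds the higher of the two numbers, and the gap down to compound 1 lies beyond the scatter. These two compounds differ in more than one place, so their gap cannot be assigned to any single change. Compound 3 `Cc1ccc(C2CC(c3ccc(OCc4ccccc4)cc3)=NN2c2ccc(S(N)(=O)=O)cc2)cc1` comes from compound 2 by one change, methyl in place of chloro on an aromatic carbon in sum: methyl in place of chloro on an aromatic carbon, para to a large group, which turns 4-chlorophenyl into 4-methylphenyl. Going by the values given here, no measured pair isolates this change. Among the compounds with values here, the only pointer is compound 1, which carries the same 4-methylphenyl group and gives 7000 nM but also differs from compound 3 elsewhere. A small fall is therefore expected, not beyond the scatter. The estimated 1.4-fold lower number from compound 2 to compound 3 (0.13 log units; within the scatter) is expected to remain a minor move in this assay and no more than that. In this assay compound 3 is estimated at 11000 nM with an expected range from 5000 nM to 25000 nM for repeat measurements.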

Compound 3, half-maximal cytotoxic concentration: 32000 nM
Estimate against measurement, compound 3: 2.9-fold (0.46 log units) below; measured number above the stated range.
By their numbers in this assay, from the lowest: compound 1; then compound 2; then compound 3.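

In this assay, going by these compounds alone, the first one-place reading at this position is a 2.1-fold higher number from compound 2 to compound 3 (0.33 log units; beyond the scatter), so methyl in place of chloro on an aromatic carbon, para to a large group, goes with lower toxicity in this test, by a step beyond the scatter. Within the data shown here, the benzyloxy group can now also be read on its own, with the 4-methylphenyl group held fixed: benzyloxy in place of hydrogen on an aromatic carbon gives a 4.6-fold higher number from compound 1 to compound 3 (0.66 log units; beyond the scatter), again toward lower toxicity in this test, so both readable steps end at compound 3 with the highest number of the series so far. Nothing at hand on these compounds accounts for either step.

Still open, on these data alone, is whether the step from 4-chlorophenyl to 4-methylphenyl carries over to a compound without the benzyloxy group, and whether the benzyloxy step holds alongside 4-chlorophenyl. Also open, as far as these compounds go, is how this read-out responds to an amine, a carboxylic acid or a longer chain such as propyl in the place of the methyl, or to methoxy in the place of benzyloxy.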